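A few compounds are considered here, and "the series" means these few. Any claim that something is new, unique, unknown or untested is made for them only; others in the source may bear on it.

Measured so far in a functional assay on HUVEC cells (Homo sapiens); on this read-out lower numbers stand for an effect already at smaller amounts and higher numbers for an effect only at larger amounts of compound:
- compound 1 `COC1=C(C)C(=O)/C(=C(O)/C=C/c2cc(C)cc(C)c2)C(=O)C1(C)C`: < 4 ug/mL, a limit
- compound 2 `C=Cc1ccccc1/C=C/C(O)=C1/C(=O)C(C)=C(OC)C(C)(C)C1=O`: < 1.1 ug/mL, a limit

Going by the values given here, compound 2 stands only at a limit, < 1.1 ug/mL, and the one other value, that of compound 1, is a limit as well. Compound 3 `COC1=C(C)C(=O)/C(=C(O)/C=C/c2nccs2)C(=O)C1(C)C` differs from compound 2 as follows: 1,3-thiazol-2-yl in place of 2-vinylphenyl on a double-bonded chain carbon bound to a double-bonded chain carbon. Among the compounds with values here, the one measured step at the same place, a step that the two limits leave unreadable from compound 1 to compound 2, has no readable size, so it sets neither size nor direction in this assay. The expectation is therefore an at least 1.3-fold higher number from compound 2 to compound 3 (0.13 log units; that floor lies within the scatter), with no step beyond the scatter anticipated. For compound 3 the estimated value is 1.5 ug/mL, with an expected range of 0.4 ug/mL to 6 ug/mL.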

Compound 3, concentration for half-maximal effect: < 4 ug/mL
Compound 3 was reported as a limit; the forecaster's own chance of this, stated with the estimate: 50%; the middle value does not contradict the limit.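

In this assay, the steps among compound 1, compound 2 and compound 3 cannot be read, as all three values are limits. Going by these compounds, whether 1,3-thiazol-2-yl, 2-vinylphenyl and 3,5-dimethylphenyl differ at all in this assay remains open.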